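Swapping a bromine for a pyrrolidine ring: an estimate

The source may hold more compounds than are shown below. What is called first, only, known or untested is meant among the compounds shown, and "the series" means these compounds.

Of the compounds shown here, three sharing one core have been measured in a functional assay on SK-OV-3 cells (Homo sapiens) for antiproliferative activity, read by MTT assay, with a stated time of 24 h; on this read-out lower numbers stand for stronger inhibition and higher numbers for weaker inhibition. Compound 1 `COc1cccc(/C=C/C(=O)c2ccc(OC)c3c2OC(C)(C)C=C3)c1` gives 9360 nM in this assay. Compound 2 `COc1ccc(C(=O)/C=C/c2cccc(F)c2)c2c1C=CC(C)(C)O2` gives only a limit of the assay, > 10000 nM. Compound 3 `COc1ccc(C(=O)/C=C/c2ccc(Br)cc2)c2c1C=CC(C)(C)O2` likewise gives only a limit, > 10000 nM. Compound 3 thus stands at the limit of > 10000 nM in this assay, at which 2 of the 3 values shown sit, and its true number is not known. The step of an at least 1.0-fold higher number from compound 1 to compound 3 (0.02 log units; that floor lies within the scatter) has only a floor, and the step that the two limits leave unreadable from compound 2 to compound 3 cannot be read at all.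

Compound 4 `COc1ccc(C(=O)/C=C/c2ccc(N3CCCC3)cc2)c2c1C=CC(C)(C)O2` differs from compound 3 by one change: pyrrolidin-1-yl in place of bromo on an aromatic carbon. For the measured compounds named here, no measured pair shows this exchange or anything resembling it, and both steps leading to compound 3 end at a limit, so they give no direction for it. With nothing to push the expectation either way, the estimated step is an at least 1.1-fold lower number from compound 3 to compound 4 (0.04 log units; that floor lies within the scatter), with a real chance that the assay again reports only a limit. The estimate for compound 4 in this assay is 9000 nM, expected to fall between 2500 nM and 25000 nM.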

Compound 4, half-maximal inhibitory concentration: 7370 nM
For compound 4 the middle estimate is 1.2-fold (0.09 log units) above the measured one; measured number inside the range.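

Placing pyrrolidin-1-yl where compound 3 carries bromo gives a measured number in this assay, so this aromatic carbon can take a group of 5 heavy atoms, ring included, and still yield a reading. The change reads as an at least 1.3-fold lower number from compound 3 to compound 4 (0.13 log units; that floor lies within the scatter), which alone shows no difference larger than ordinary assay scatter. The true size could be larger, yet it stays unknown, as compound 3 has only a limit: the limit of > 10000 nM in this assay, at which 2 of the 4 values shown sit.

Still open, from the compounds shown here alone, is whether the nitrogen or the ring matters more, which an open-chain dimethylamino group at the same place could help separate. A piperidine or morpholine ring there could show whether ring size or a second hetero atom shifts the number, and whether any such change moves it beyond the scatter.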